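The source may report more compounds than this note shows. Statements on the series, on what has been measured and on what is new or still open speak of the compounds shown alone.

The measured compounds:
Compound 1 `Cn1c(C(=O)NCc2ccc(S(=O)(=O)c3ccccc3)cc2)cc2cnccc21` gives > 10000 nM in a functional assay on A2780 cells (Homo sapiens) for inhibition, read by sulforhodamine B assay, with a stated time of 72 h (a higher number here means a weaker inhibitor, a lower number a stronger inhibitor), which is a limit of the assay rather than a number.
Compound 2 `O=C(NCc1ccc(S(=O)(=O)c2ccccc2C(F)(F)F)cc1)c1cc2cnccc2[nH]1` gives 25 nM in this assay.
Compound 3 `O=C(NCc1ccc(S(=O)(=O)c2ccccc2)cc1)c1ccc2nncn2c1` gives > 10000 nM in this assay, again a limit rather than a number.

Compound 3 therefore stands at the weak end of what has been seen: its value is only a limit, and (the limit of > 10000 nM in this assay, at which 2 of the 3 values shown sit). The step to compound 4 `O=C(NCc1ccc(S(=O)(=O)c2ccccc2)cc1)c1cc2cnccc2[nH]1` alters the group on the carbonyl carbon: a group of 9 heavy atoms (7 carbon, 2 nitrogen; one five-membered aromatic ring with 1 hetero atom, one six-membered aromatic ring with 1 hetero atom) in place of a group of 9 heavy atoms (6 carbon, 3 nitrogen; one five-membered aromatic ring with 3 hetero atoms, one six-membered aromatic ring with 1 hetero atom), on a carbonyl carbon. The group that enters is the same one carried by compound 2, while compound 1 carries a related group that lacks the hydrogen-bond donor. Within the data shown here, no step between measured compounds is available to calibrate this change, so the expectation rests on those two comparisons. Compound 4 is expected to be a markedly stronger inhibitor than compound 3 in this assay, a step estimated at an at least 50-fold lower number from compound 3 to compound 4 (1.69 log units; beyond the scatter). The expectation is anchored mainly because compound 2 gives 25 nM with the same entering group plus an additional trifluoromethyl group. Compound 4 is estimated at 200 nM, with a range from 30 nM to 2000 nM.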

Compound 4, half-maximal inhibitory concentration: 18 nM
For compound 4 the middle estimate is 11-fold (1.05 log units) above the measured one, outside the stated range (below it).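

Two single changes each separate activity from inactivity at this part of the molecule: hydrogen in place of methyl on the aromatic nitrogen gives an at least 550-fold lower number from compound 1 to compound 4 (2.74 log units; beyond the scatter), and the exchange of the group on the carbonyl carbon gives an at least 550-fold lower number from compound 3 to compound 4 (2.74 log units; beyond the scatter). The trifluoromethyl group, by contrast, makes no measurable difference, since hydrogen in its place on an aromatic carbon gives a 1.4-fold lower number from compound 2 to compound 4 (0.14 log units; within the scatter). The two large steps have no upper end, as each starts from a limit and not from a number: the limit of > 10000 nM in this assay, at which 2 of the 4 values shown sit.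

As far as these compounds go, how a chlorine or a methoxy group on that aromatic carbon would read in this assay remains open. The compounds shown also leave open whether any group other than methyl on the aromatic nitrogen, such as ethyl, would be tolerated.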